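A few compounds are considered here, and "the series" means these few. Any claim that something is new, unique, unknown or untested is made for them only; others in the source may bear on it.

Three measured compounds share one core and differ only in the chain attached to the amide. Compound 1 `CCC(=O)Nc1ccc(S(=O)(=O)Oc2ccccc2I)cc1` gives 8100 nM in a functional assay on MCF7 cells (Homo sapiens) for antiproliferative activity, read by sulforhodamine B assay, with a stated time of 48 h; a lower number here means a stronger inhibitor, a higher number a weaker inhibitor. Compound 2 `CCCC(=O)Nc1ccc(S(=O)(=O)Oc2ccccc2I)cc1` gives 9700 nM, and compound 3 `O=C(CCCl)Nc1ccc(S(=O)(=O)Oc2ccccc2I)cc1` gives 8900 nM; the steps of a 1.2-fold higher number from compound 1 to compound 2 (0.08 log units; within the scatter), a 1.1-fold higher number from compound 1 to compound 3 (0.04 log units; within the scatter) and a 1.1-fold lower number from compound 2 to compound 3 (0.04 log units; within the scatter) all stay within the scatter, so compound 3 sits among three numbers that cannot be told apart. Compound 4 `CCCNC(=O)Nc1ccc(S(=O)(=O)Oc2ccccc2I)cc1` differs from compound 3 by propylamino in place of 2-chloroethyl on a carbonyl carbon. Within the data shown here, no measured step alters this part of the amide; the three measured steps only swap hydrogen, methyl and chloro on the chain, and each stayed within the scatter. The expected step is therefore small, a 1.0-fold higher number from compound 3 to compound 4 (0.00 log units; within the scatter). Compound 4 is estimated at 9000 nM, with a range from 4000 nM to 20000 nM.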

Compound 4, half-maximal inhibitory concentration: 2900 nM
The estimate for compound 4 lay 3.1-fold (0.49 log units) above the measured number; measured number below the stated range.
By their numbers in this assay, from the lowest: compound 4; then compounds 1, 3 and 2 (each within the scatter of the next).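

In this assay, among these compounds, this position responds to a change at the atom on the carbonyl carbon, although swaps further out along the chain did not separate the earlier compounds: the new steps are (a 2.8-fold lower number from compound 1 to compound 4 (0.45 log units; beyond the scatter)) and (a 3.1-fold lower number from compound 3 to compound 4 (0.49 log units; beyond the scatter)). The closest pair is propyl and propylamino (a 3.3-fold lower number from compound 2 to compound 4 (0.52 log units; beyond the scatter)), where the entering group adds a nitrogen and a hydrogen-bond donor to the same chain. Nothing available explains the shift. As far as these compounds go, whether methylamino, butylamino or dimethylamino on the carbonyl carbon would give a similar number remains open.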